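The source may report more compounds than this note shows. Statements on the series, on what has been measured and on what is new or still open speak of the compounds shown alone.

Working notes on the series. All three measured compounds share the core seen in compound 1 `CCOC(=O)C1=Cc2ccccc2OC1(OCc1cc(-c2ccc(F)cc2F)no1)C(F)(F)F`, compound 2 `CCOC(=O)C1=Cc2ccccc2OC1(OCc1cn(CC(=O)NC2CCCCC2)nn1)C(F)(F)F` and compound 3 `O=C(O)C1=Cc2ccccc2OC1(OCc1cc(-c2ccc3ccccc3c2)no1)C(F)(F)F`, and differ in the ether-linked side chain. In a functional assay on A549 cells (Homo sapiens) for inhibition, read by MTT assay, with a stated time of 24 h (on this read-out higher numbers stand for weaker inhibition and lower numbers for stronger inhibition), compound 1 returns only a limit, > 150000 nM. Compound 3 likewise returns only a limit in this assay, > 150000 nM. Within the data shown here, compound 2 is the one compound with a number in this assay, 9900 nM, and it therefore stands alone against (the limit of > 150000 nM in this assay, at which 2 of the 3 values shown sit), with no measured step to any neighbour.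

Compound 4 `CCOC(=O)C1=Cc2ccccc2OC1(OCc1cn(CC(=O)Nc2ccccc2F)nn1)C(F)(F)F` is the next in line. It keeps the ester, the triazole and the amide of compound 2 and changes the amide substituent: 2-fluorophenyl in place of cyclohexyl on an amide-type nitrogen. Among the measured compounds shown here, no measured pair tests a change of this kind, so no direction can be read from the data. The step from compound 2 is expected to stay within the usual scatter, a 1.0-fold higher number from compound 2 to compound 4 (0.00 log units; within the scatter). Compound 4 is accordingly estimated at 10000 nM in this assay, with a range from 3000 nM to 40000 nM.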

Compound 4, half-maximal inhibitory concentration: 50100 nM
Beside the measured number, compound 4's estimate is 5.0-fold (0.70 log units) below it; measured number outside the range, above it.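

Among these compounds, replacing cyclohexyl with 2-fluorophenyl on an amide-type nitrogen gives the first measured step in this assay, a 5.1-fold higher number from compound 2 to compound 4 (0.70 log units; beyond the scatter). The amide substituent is therefore a position that moves the read-out, and this change moves it toward weaker inhibition. Compound 4 still returns a number, whereas compound 1 and compound 3 return only a limit: the limit of > 150000 nM in this assay, at which 2 of the 4 values shown sit.

The compounds shown do not separate the contribution of the aromatic ring from that of the fluorine, and a plain phenyl on the same nitrogen would divide the two. Also open, on these data alone, is how a smaller ring such as cyclopropyl, or a longer chain such as n-hexyl, would read at this position.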